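A few compounds are considered here, and "the series" means these few. Any claim that something is new, unique, unknown or untested is made for them only; others in the source may bear on it.

Three compounds share one core and differ only in the aryl ester on the oxygen next to a carbonyl group. Compound 1 `COC(=O)c1cc(F)ccc1OC(=O)COc1cc(O)c2c(=O)cc(-c3ccccc3)oc2c1` is tested in an ADME assay on cells (T-cell, Mus musculus, strain BALB/c) for cytotoxicity, read by MTT assay, with a stated time of 48 h (on this read-out higher numbers stand for lower toxicity in this test and lower numbers for higher toxicity in this test), where compound 1 gives 389000 nM. Among the three numbers measured, compound 1 stands second highest; its nearest neighbour is compound 3 `COC(=O)c1c(Br)cc(Br)cc1OC(=O)COc1cc(O)c2c(=O)cc(-c3ccccc3)oc2c1`, for which compound 3 gives 398000 nM, and its furthest is compound 2 `COC(=O)c1ccc(C)cc1OC(=O)COc1cc(O)c2c(=O)cc(-c3ccccc3)oc2c1`, for which compound 2 gives 250000 nM, all three within the usual scatter of one another.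

Compound 4 `COC(=O)c1c(Br)cccc1OC(=O)COc1cc(O)c2c(=O)cc(-c3ccccc3)oc2c1` has not yet been measured. It differs from compound 1 by a group of 11 heavy atoms (8 carbon, 2 oxygen, 1 bromine; one six-membered aromatic ring of carbon only) in place of a group of 11 heavy atoms (8 carbon, 2 oxygen, 1 fluorine; one six-membered aromatic ring of carbon only), on an oxygen next to a carbonyl group.

Within the data shown here, the one measured step of the same kind, a swap of the substituent on this aryl ring, is a 1.6-fold lower number from compound 1 to compound 2 (0.19 log units; within the scatter), and compound 3 with two bromines on the ring gave a number close to that of compound 1. Compound 4 is therefore expected to give 380000 nM, in a range from 200000 nM to 700000 nM. The step implied by this estimate, a 1.0-fold lower number from compound 1 to compound 4 (0.01 log units; within the scatter), is expected to stay within the scatter.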

Compound 4, half-maximal cytotoxic concentration: 388000 nM
Estimate against measurement, compound 4: 1.0-fold (0.01 log units) below, and the stated range covers the measured number.
By their numbers in this assay, from the lowest: compounds 2, 4, 1 and 3 (each within the scatter of the next).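

In this assay, setting the bromine-bearing aryl group in place of the fluorine-bearing one gives a 1.0-fold lower number from compound 1 to compound 4 (0.00 log units; within the scatter), and setting it in place of the halogen-free group gives a 1.6-fold higher number from compound 2 to compound 4 (0.19 log units; within the scatter), while hydrogen in place of bromo on an aromatic carbon gives a 1.0-fold lower number from compound 3 to compound 4 (0.01 log units; within the scatter). Among these compounds, that last step is the first here in which a bromo group is exchanged for hydrogen and nothing else changes, and like the other two steps it stays within the scatter, so this test separates none of these aryl esters from one another. Nothing available explains why these groups give such similar numbers.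

Going by these compounds, whether an amine or a carboxylic acid on this aryl ring would also stay within the scatter remains open. So does the effect of replacing the aryl group on this oxygen with a longer carbon chain.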